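Adding a Second Fluoro Group to Compound 3

The compounds below may be only part of what the source reports. "The series", "measured", "known", "first", "only" and "open" are said of these compounds alone.

In a functional assay (aorta) for inhibition, with Rattus norvegicus as the target (a lower number here means that less compound is needed, a higher number that more compound is needed for the effect), compound 1 (`O=C1C=CC(=O)c2ncccc21`) gives 519 nM, compound 2 (`O=C1C(Nc2ccc(F)cc2)=CC(=O)c2ncccc21`) gives 541 nM, and compound 3 (`O=C1C(Nc2cccc(F)c2)=CC(=O)c2ncccc21`) gives 805 nM. Compound 3 therefore lies within the scatter of both other compounds, and the three values cannot be ranked. Compound 4 (`O=C1C(Nc2ccc(F)c(F)c2)=CC(=O)c2ncccc21`) differs from compound 3 by a single change: fluoro in place of hydrogen on an aromatic carbon, ortho to a fluoro group and para to a large group (fluoro in place of hydrogen on an aromatic carbon). For the measured compounds named here, no measured pair shows this change, so no shift beyond the scatter is expected in this assay, in either direction. The expected step is small, a 1.2-fold lower number from compound 3 to compound 4 (0.06 log units; within the scatter). Compound 4 is estimated at 700 nM, with an expected range of 320 nM to 1500 nM.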

Compound 4, half-maximal effective concentration: 251 nM
Beside the measured number, compound 4's estimate is 2.8-fold (0.45 log units) above it; measured number outside the range, below it.
By their numbers in this assay, from the lowest: compound 4; then compounds 1, 2 and 3 (each within the scatter of the next).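

In this assay, fluoro in place of hydrogen at this position, ortho to a fluoro group and para to a large group, moves the number beyond the scatter, with a 3.2-fold lower number from compound 3 to compound 4 (0.51 log units; beyond the scatter) and with a 2.2-fold lower number from compound 2 to compound 4 (0.33 log units; beyond the scatter). Neither single-fluoro compound had shown any such separation from another compound. Nothing available here accounts for the size of this step. The compounds shown leave open whether a chloro group or a methoxy group at this position would give a similar step, and whether a third fluoro group elsewhere on the ring would lower the number further.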